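From 3-fluorophenyl to 2-methylphenyl on the sulfonyl sulfur

This account rests on a few compounds, and the source may have more. Where it says the series, first, only, none or still open, it means among the compounds named here.

In a functional assay on HEK293 cells (Homo sapiens) for cytotoxicity (on this read-out higher numbers stand for lower toxicity in this test and lower numbers for higher toxicity in this test), compound 1 (`COc1ccc([C@H]2CC(=O)N(c3cccc(O)c3)C2)cc1OC1CCCC1`) gives > 10000 nM, which is a limit of the assay and not a number. In this assay compound 2 (`COc1ccc([C@H]2CC(=O)N(c3cccc(NS(=O)(=O)c4cccc(F)c4)c3)C2)cc1OC1CCCC1`) gives > 10000 nM, likewise a limit and not a number. Compound 2 therefore has no exact position in the series.

Compound 3 (`COc1ccc([C@H]2CC(=O)N(c3cccc(NS(=O)(=O)c4ccccc4C)c3)C2)cc1OC1CCCC1`) differs from compound 2 at one place: 2-methylphenyl in place of 3-fluorophenyl on a sulfonyl sulfur. In words, 2-methylphenyl takes the place of 3-fluorophenyl on a sulfonyl sulfur.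

Among the compounds with values here, the only measured step available is a step that the two limits leave unreadable from compound 1 to compound 2, and it supplies no size. It also lies at a different place, since it puts ((3-fluorophenyl)sulfonyl)amino in place of hydroxy on an aromatic carbon. The remaining evidence is the limit of > 10000 nM in this assay, at which 2 of the 2 values shown sit. On that basis, no step beyond the usual scatter is expected in this assay, in either direction, and another limit is the most likely report. The expected step is a step that the limit leaves unreadable from compound 2 to compound 3. For compound 3 the estimate is 15000 nM, with an expected range from 7000 nM to 40000 nM.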

Compound 3, half-maximal cytotoxic concentration: > 10000 nM
Compound 3: a limit, no number; the forecaster's own chance of this, stated with the estimate: 90%; the middle value is on the limit's open side.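

In this assay compound 3 gives > 10000 nM, a limit of the assay and not a number, and no step can be read between compound 3 and either compound 1 or compound 2. The compounds shown leave open how far each lies beyond the limit, and whether any of these changes shifts the read-out at all: the limit of > 10000 nM in this assay, at which 3 of the 3 values shown sit.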